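The source may report more compounds than this note shows. Statements on the series, on what has been measured and on what is new or still open speak of the compounds shown alone.

In an ADME assay on MT4 cells (Homo sapiens) for cytotoxicity, read by MTT assay (a lower number here means that less compound is tolerated, a higher number that more compound is tolerated), compound 1 `Cc1cc(C)cc(S(=O)(=O)c2c(C(=O)Nc3ccc(O)cc3)[nH]c3ccc(Cl)cc23)c1` gives 18100 nM and compound 2 `Cc1cc(C)cc(S(=O)(=O)c2c(C(=O)NCc3ccccc3O)[nH]c3ccc(Cl)cc23)c1` gives 23800 nM while compound 3 `Cc1cc(C)cc(S(=O)(=O)c2c(C(=O)Nc3ccc(CO)cc3)[nH]c3ccc(Cl)cc23)c1` gives 39600 nM within a narrow range. Compound 3 stands apart only from compound 1, through a 2.2-fold higher number from compound 1 to compound 3 (0.34 log units; beyond the scatter) at an aromatic carbon, and that step lies away from the place changed next. The next change leads to compound 4 `Cc1cc(C)cc(S(=O)(=O)c2c(C(=O)NCC(=O)NCc3ccccc3O)[nH]c3ccc(Cl)cc23)c1` and consists of a group of 12 heavy atoms (9 carbon, 1 nitrogen, 2 oxygen; one six-membered aromatic ring of carbon only) in place of a group of 8 heavy atoms (7 carbon, 1 oxygen; one six-membered aromatic ring of carbon only), on an amide-type nitrogen as the difference from compound 3. Two measured steps fall on that same kind of nitrogen, a 1.3-fold higher number from compound 1 to compound 2 (0.12 log units; within the scatter) and a 1.7-fold higher number from compound 2 to compound 3 (0.22 log units; within the scatter) and neither clears the scatter. Among the compounds with values here, the entering group has no counterpart among the measured compounds, so the range is kept wide. The step expected is a 1.3-fold lower number from compound 3 to compound 4 (0.12 log units; within the scatter) in this assay and no change beyond the scatter is foreseen. For compound 4 the estimated value is 30000 nM with an expected range from 13000 nM to 65000 nM in this assay.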

Compound 4, half-maximal cytotoxic concentration: > 47300 nM
Compound 4 gave a limit, no number; the forecaster's own chance of this, stated with the estimate: 15%; at least 1.5-fold (0.19 log units) between middle value and limit.
By their numbers in this assay, from the lowest: compounds 1, 2 and 3 (each within the scatter of the next, the first and the last beyond it). At a limit, above all of these: compound 4.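

In this assay, compound 4 returns a limit and not a number: the limit of > 47300 nM in this assay, at which 1 of the 4 values shown sits. Read against that limit, the change gives an at least 1.1-fold higher number from compound 3 to compound 4 (0.07 log units; that floor lies within the scatter) and an at least 1.9-fold higher number from compound 2 to compound 4 (0.29 log units; that floor lies within the scatter), while only an at least 2.6-fold higher number from compound 1 to compound 4 (0.41 log units; beyond the scatter) clears the scatter. The earlier steps shown here on this amide-type nitrogen involved only smaller groups, and the group of 12 heavy atoms now shows that a larger entrant with a second carbonyl brings no fall in the number against any of compounds 1, 2 or 3.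

Going by these compounds, the true size of the steps from compound 2 and compound 3 stays open, as their floors do not separate them from the scatter. Also open, on these data alone, is whether a longer chain on this nitrogen, or an amine or a carboxylic acid in place of the 2-hydroxybenzyl group, would give a readable number in this assay.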